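The source may hold more compounds than are shown below. What is called first, only, known or untested is meant among the compounds shown, and "the series" means these compounds.

Working notes on the series. For the measured compounds named here, compound 1 `O=C(c1cn(-c2ccccc2)nc1-c1cccnc1)N1CCC(Cc2ccccc2)CC1` is the one compound of the set to return a number in a functional assay on HL-60 cells (Homo sapiens) for cytotoxicity, read by MTT assay, with a stated time of 48 h; on this read-out higher numbers stand for weaker inhibition and lower numbers for stronger inhibition: compound 1 gives 16100 nM there. Compound 2 `CC(C)(C)c1ccc(OC(=O)c2cn(-c3ccccc3)nc2-c2cccnc2)cc1` reaches only a limit of this assay, and for compound 2 the entry is > 100000 nM, a limit and not a number. Compound 3 `O=C(Oc1ccc2ccccc2c1)c1cn(-c2ccccc2)nc1-c1cccnc1` has no number in this assay at all; the entry for compound 3 reads "nd(insoluble)" (no result reported), so compound 3 cannot be placed against compound 1. Of the three entries shown, one is a number, one is a limit and one is missing; the limit of > 100000 nM in this assay, at which 1 of the 3 values shown sits, marks the limit.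

Compound 4 `O=C(Oc1ccc2ccccc2c1)c1cn(-c2ccccc2)nc1-c1ccncc1` keeps every atom of compound 3 and differs in one place: pyridin-4-yl in place of pyridin-3-yl on an aromatic carbon. Going by the values given here, no measured step between two compounds covers a change of this kind, so no size can be read off for it, and the step from compound 3 to compound 4 in this assay cannot be set against a measured one. Given that compound 3 gave no result, the expectation for compound 4 in this assay is that a limit or no number is the likeliest outcome. Should a number be obtained, compound 4 is estimated at 80000 nM, with a range from 20000 nM to 300000 nM.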

Compound 4, half-maximal inhibitory concentration: > 100000 nM
Compound 4: a limit, no number; the forecaster's own chance of this, stated with the estimate: 60%; middle value at least 1.2-fold (0.09 log units) away from the limit.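

No new step can be read between compound 3 and compound 4 in this assay: compound 3 has no reported result there. Compound 4 gives > 100000 nM, which is a limit and not a number. The compounds shown leave open whether pyridin-4-yl in place of pyridin-3-yl changes the read-out in this assay at all.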